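The compounds below may be only part of what the source reports. "The series", "measured", "known", "first", "only" and "open" are said of these compounds alone.

Measured compounds in the series:
compound 1 `C[C@@H](CO)Nc1nc(C(=O)NCc2ccc(F)cc2)c(O)c2ncccc12`, a functional assay on HCT-116 cells (Homo sapiens) for cytotoxicity, read by MTT assay, with a stated time of 72 h; on this read-out lower numbers stand for stronger inhibition and higher numbers for weaker inhibition: "not determined" (no result reported)
compound 2 `C[C@@H](Nc1c(C(=O)NCc2ccc(F)cc2)nc(Br)c2cccnc12)c1ccccc1`, this assay: > 20000 nM
compound 3 `O=C(NCc1ccc(F)cc1)c1nc(NCCO)c2cccnc2c1O`, this assay: "not determined" (no result reported)

Compound 1 and compound 3 carry no result in this assay. For compound 2 the entry is a limit of the assay, not a number, so compound 2 sits at the limit of > 20000 nM in this assay, at which 1 of the 3 values shown sits, among the three entries shown. Among the measured compounds shown here, no step between two measured compounds exists here, so there is nothing to compare against.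

Compound 4 `Nc1cccc(Nc2c(C(=O)NCc3ccc(F)cc3)nc(Br)c3cccnc23)c1` differs from compound 2 in one place: 3-aminophenyl in place of 1-phenylethyl on a nitrogen on an aromatic ring. For the measured compounds named here, with compound 2 at a limit and no measured step to lean on, the step expected in this assay from compound 2 to compound 4 is set as a step that the limit leaves unreadable from compound 2 to compound 4, that is, none beyond the scatter, and a limit is again the likelier outcome. Compound 4 is therefore estimated at 25000 nM, within 5000 nM to 100000 nM.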

Compound 4, half-maximal inhibitory concentration: > 10000 nM
Compound 4 was reported as a limit (the forecaster's own chance of this, stated with the estimate: 70%); the middle value is on the limit's open side.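

Compound 2 and compound 4 are both reported only as limits in this assay, so no step can be read between them. From the compounds shown here alone, whether 3-aminophenyl in place of 1-phenylethyl changes the read-out at all stays open.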